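The compounds below may be only part of what the source reports. "The series", "measured", "known", "first", "only" and "open" are said of these compounds alone.

For the measured compounds named here, compound 3 `N#Cc1nc2c(-c3nc4ccccc4[nH]3)c(N)n(CCCN3CCCCC3)c2nc1C#N` gives 1010 nM in a functional assay on HL60/MX2 cells (Homo sapiens) for antiproliferative activity, read by MTT assay, with a stated time of 48 h (a lower number here means a stronger inhibitor, a higher number a weaker inhibitor), the only actual number so far. Compound 1 `CCn1c(N)c(-c2nc3ccccc3[nH]2)c2nc(C#N)c(C#N)nc21` gives > 50000 nM in this assay, and this is a limit of the assay. Compound 2 `N#Cc1nc2c(-c3nc4ccccc4[nH]3)c(N)n(CCN3CCCC3)c2nc1C#N` gives > 50000 nM, again a limit.

Next is compound 4 `CCN(CC)CCCCn1c(N)c(-c2nc3ccccc3[nH]2)c2nc(C#N)c(C#N)nc21`, which differs from compound 3 as follows: (diethylamino)methyl in place of piperidin-1-yl on a saturated chain carbon, three bonds along the chain from an aromatic nitrogen. The same difference, cut further out, reads 3-(piperidin-1-yl)propyl to 4-(diethylamino)butyl.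

Going by the values given here, two measured steps bear on this change: an at least 49-fold lower number from compound 1 to compound 3 (1.69 log units; beyond the scatter) and an at least 49-fold lower number from compound 2 to compound 3 (1.69 log units; beyond the scatter). Both are large, and both start from the limit of > 50000 nM in this assay, at which 2 of the 3 values shown sit. The third, a step that the two limits leave unreadable from compound 1 to compound 2, gives no size. All three changes sit two bonds along the chain from an aromatic nitrogen, whereas the new change sits three bonds along, so none of them measures it directly. They do show that changes to this chain can move the number strongly, which argues for a wide range.

Among the compounds with values here, with no measured step for this exact change, the expectation starts from compound 3 at 1010 nM, and no step beyond the scatter is expected in this assay, in either direction. The expected result is a 1.2-fold higher number from compound 3 to compound 4 (0.07 log units; within the scatter). The estimate for compound 4 is 1200 nM, with an expected range from 250 nM to 8000 nM.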

Compound 4, half-maximal inhibitory concentration: 1550 nM
For compound 4 the middle estimate is 1.3-fold (0.11 log units) below the measured one; the measured number falls inside the stated range.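

In this assay, (diethylamino)methyl in place of piperidin-1-yl, on a saturated chain carbon three bonds along the chain from an aromatic nitrogen, gives a 1.5-fold higher number from compound 3 to compound 4 (0.19 log units; within the scatter), so a 4-(diethylamino)butyl chain and a 3-(piperidin-1-yl)propyl chain cannot be told apart here. A cyclic amine end is therefore not required for a measurable number in this series, and a second chain now gives an at least 32-fold lower number from compound 2 to compound 4 (1.50 log units; beyond the scatter) and an at least 32-fold lower number from compound 1 to compound 4 (1.50 log units; beyond the scatter), both large. Both of these steps start from a limit, so each gives only a minimum size: the limit of > 50000 nM in this assay, at which 2 of the 4 values shown sit.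

The chain length and the amine end change together from compound 3 to compound 4, so the compounds shown do not separate the two, and a 3-(diethylamino)propyl chain would bear directly on that question. Also open, on these data alone, is whether the number holds with a morpholine ring at the chain end, or with a chain longer than 4-(diethylamino)butyl.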